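A few compounds are considered here, and "the series" means these few. Any claim that something is new, unique, unknown or untested is made for them only; others in the source may bear on it.

Working notes on the series. In a functional assay on L5178Y cells (Mus musculus) for inhibition, read by MTT assay, with a stated time of 24 h (on this read-out higher numbers stand for weaker inhibition and lower numbers for stronger inhibition), compound 1 (`Oc1ccc([C@@H]2C/C(=N\Nc3ccccc3)c3c(O)cc(O)cc3O2)cc1`) gives >= 11300 nM, which is a limit and not a number. Compound 2 (`Oc1ccc([C@@H]2C/C(=N\Nc3ccc(Br)cn3)c3c(O)cc(O)cc3O2)cc1`) gives >= 11300 nM, again a limit. Compound 3 (`O=C(Cc1c[nH]c2ccccc12)N/N=C1\C[C@@H](c2ccc(O)cc2)Oc2cc(O)cc(O)c21`) gives >= 11300 nM, also a limit. Compound 1 therefore has no measured position of its own and cannot be ranked against the other two.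

Compound 4 (`O=C(N/N=C1\C[C@@H](c2ccc(O)cc2)Oc2cc(O)cc(O)c21)OCc1ccccc1`) has benzyloxycarbonyl in place of phenyl on an amine nitrogen.

Within the data shown here, the only measured step that changes the group at this place is a step that the two limits leave unreadable from compound 1 to compound 2. Among the measured compounds shown here, it offers no size to carry over, and the series so far holds no numerical reading in this assay. For the measured compounds named here, the sole guide is the limit of >= 11300 nM in this assay, at which 3 of the 3 values shown sit. On the basis of the limit of >= 11300 nM in this assay, at which 3 of the 3 values shown sit, no step beyond the scatter is expected in either direction, and a further limit is the likeliest report for compound 4. The expected change is a step that the limit leaves unreadable from compound 1 to compound 4, and this estimate carries little weight. Compound 4 is estimated at about 12000 nM. The estimated range for compound 4 runs from 5000 nM to 25000 nM.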

Compound 4, half-maximal inhibitory concentration: >= 11300 nM
Compound 4 gave a limit, no number (the forecaster's own chance of this, stated with the estimate: 70%); the middle value is on the limit's open side.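

In this assay compound 4 gives >= 11300 nM, which is a limit and not a number. The steps to compound 4 from compound 1, compound 2 and compound 3 therefore cannot be read. Still open is whether changing the group on the amine nitrogen shifts inhibition at all, since the series offers only this: the limit of >= 11300 nM in this assay, at which 4 of the 4 values shown sit.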